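Shortening the selenium-bound chain of compound 1

This account rests on a few compounds, and the source may have more. Where it says the series, first, only, none or still open, it means among the compounds named here.

Compound 1 `CCCCC[Se]c1nc(NCc2ccc(SC)cc2)c2ccccc2n1` gives 88200 nM in an ADME assay on BEAS-2B cells (Homo sapiens) for cytotoxicity, read by MTT assay, with a stated time of 72 h; on this read-out higher numbers stand for weaker inhibition of growth and lower numbers for stronger inhibition of growth.
Compound 2 `CCCCC[Se]c1nc(NCc2ccccc2)c2ccccc2n1` gives > 100000 nM, a limit of the assay.
Compound 3 `CSc1nc(NCc2ccc([Se]C)cc2)c2ccccc2n1` gives > 100000 nM, a limit of the assay.

Among these three, compound 1 is the only one with a number in this assay. Compound 2 stops at a limit of the assay. Compound 3 stops at a limit as well (the limit of > 100000 nM in this assay, at which 2 of the 3 values shown sit). Going by the values given here, the one measured step, an at least 1.1-fold higher number from compound 1 to compound 2 (0.05 log units; that floor lies within the scatter), stays within the scatter. Compound 4 `CSc1ccc(CNc2nc([Se]C)nc3ccccc23)cc1` differs from compound 1 by hydrogen in place of butyl on a saturated chain carbon bound to a selenium atom, with the methylsulfanyl group retained. Among the compounds with values here, no measured step touches the chain on selenium, so the direction rests on thin ground. Compound 4 is expected to give a somewhat higher number, a 1.4-fold higher number from compound 1 to compound 4 (0.13 log units; within the scatter), most likely reaching the limit. The estimate for compound 4 is 120000 nM, between 60000 nM and 250000 nM.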

Compound 4, concentration for total growth inhibition: 78500 nM
Compound 4: the middle estimate sits 1.5-fold (0.18 log units) above what was measured; measured number inside the range.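

Going by these compounds alone, the first step at the chain on selenium, pentyl to methyl with the methylsulfanyl group retained, gives a 1.1-fold lower number from compound 1 to compound 4 (0.05 log units; within the scatter) in this assay. The two numbers cannot be told apart, so for this pair the length of that chain does not register on this read-out. Compound 2 and compound 3 remain the only compounds at a limit of the assay: the limit of > 100000 nM in this assay, at which 2 of the 4 values shown sit.

The compounds shown leave open how an amine or a carboxylic acid in place of pentyl on selenium would read. They also leave open whether the pentyl to methyl exchange reads the same without the methylsulfanyl group.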